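The compounds below may be only part of what the source reports. "The series", "measured", "known", "first", "only" and "open" are said of these compounds alone.

Compound 1 `Nc1ccccc1/C=C/c1ccc(O)cc1` and compound 2 `Nc1ccc(/C=C/c2ccc(O)cc2)cc1` are built from the same atoms joined differently; the difference between the two cores is not broken down here. In a functional assay on HT-29 cells (Homo sapiens) for inhibition, read by MTT assay, with a stated time of 2 days (a higher number here means a weaker inhibitor, a lower number a stronger inhibitor), compound 1 gives only a limit, > 100 ug/mL. In this assay compound 2 gives 30.6 ug/mL. Compound 3 `COc1ccc(/C=C/c2ccccc2N)cc1` carries a methyl in place of hydrogen on an oxygen on an aromatic ring, (methyl in place of hydrogen on an oxygen on an aromatic ring). In this assay compound 3 gives 73 ug/mL, and the step of an at least 1.3-fold lower number from compound 1 to compound 3 (0.13 log units; that floor lies within the scatter) is known only as a floor because of the limit of > 100 ug/mL in this assay, at which 1 of the 3 values shown sits. Compound 2 stands lowest of the two numbers, with compound 3 beyond the scatter from it.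

Compound 4 `COc1ccc(/C=C/c2ccc(N)cc2)cc1` is not yet measured. It carries the same change from compound 2 that compound 3 carries from compound 1, (methyl in place of hydrogen on an oxygen on an aromatic ring), at a place described in the same words. The step from compound 1 to compound 3 gave no more than a floor, so for compound 4 a step of similar or smaller size is expected, a 1.2-fold lower number from compound 2 to compound 4 (0.09 log units; within the scatter). In this assay compound 4 is thus estimated at 25 ug/mL, between 10 ug/mL and 70 ug/mL.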

Compound 4, half-maximal inhibitory concentration: 0.0036 ug/mL
Estimate against measurement, compound 4: 6900-fold (3.84 log units) above; measured number outside the range, below it.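

In this assay, methyl in place of hydrogen on an oxygen on an aromatic ring gives a large step on the second core, an 8500-fold lower number from compound 2 to compound 4 (3.93 log units; beyond the scatter). Set beside the same change on the other core, the comparison stays unsettled: the same change on two cores in this assay, an at least 1.3-fold lower number (0.13 log units; that floor lies within the scatter) from compound 1 to compound 3 and an 8500-fold lower number (3.93 log units; beyond the scatter) from compound 2 to compound 4; the limit leaves it open whether they differ What this shows is that hydroxy to methoxy can bring a very large step on the core of compound 2, but it does not show that the step is of similar size on the core of compound 1, whose number is only a limit: the limit of > 100 ug/mL in this assay, at which 1 of the 4 values shown sits.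

The compounds shown leave open whether an ethyl group or a longer chain on that oxygen would give a step like that of methyl on either core. They also leave open what an amine or a carboxylic acid in place of the hydroxy group would give on the core of compound 2.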